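From Bromo to 3-Methoxyphenyl: Expected Cytotoxicity of Compound 4

A few compounds are considered here, and "the series" means these few. Any claim that something is new, unique, unknown or untested is made for them only; others in the source may bear on it.

Compound 3 `CN1Cc2ccc(OCc3ccc(Br)cc3)cc2[C@@H](O)C1` gives 37000 nM in an ADME assay on Vero cells (Chlorocebus sabaeus) for cytotoxicity, read by sulforhodamine B assay, with a stated time of 72 h (on this read-out lower numbers stand for stronger inhibition and higher numbers for weaker inhibition), the highest of the two plain numbers shown; compound 1 `CN1Cc2ccc(OCc3ccc(-c4ccccc4)cc3)cc2[C@@H](O)C1` gives 23000 nM, and these two values lie within the scatter of each other. Compound 2 `COc1ccc(COc2ccc3c(c2)[C@@H](O)CN(C)C3)cc1` reaches only > 50000 nM, which is a limit of the assay rather than a number. The step of a 1.6-fold higher number from compound 1 to compound 3 (0.21 log units; within the scatter) was small, whereas an at least 2.1-fold higher number from compound 1 to compound 2 (0.33 log units; beyond the scatter) was at least modest. Compound 4 `COc1cccc(-c2ccc(COc3ccc4c(c3)[C@@H](O)CN(C)C4)cc2)c1` arises through (3-methoxyphenyl in place of bromo on an aromatic carbon). That change undoes the bromo-for-phenyl exchange and adds a methoxy, so an expected value close to compound 1 at 23000 nM seems reasonable. Compound 4 is therefore expected near 25000 nM, between 10000 nM and 60000 nM, an expected step of a 1.5-fold lower number from compound 3 to compound 4 (0.17 log units; within the scatter) in this assay.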

Compound 4, half-maximal inhibitory concentration: 10800 nM
For compound 4 the middle estimate is 2.3-fold (0.36 log units) above the measured one; measured number inside the range.
By their numbers in this assay, from the lowest: compound 4; then compounds 1 and 3 (each within the scatter of the next). At a limit, above all of these: compound 2.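

In this assay, 3-methoxyphenyl on this aromatic carbon gives a step that bromo and phenyl did not give each other: a 3.4-fold lower number from compound 3 to compound 4 (0.53 log units; beyond the scatter). Methoxy in place of hydrogen on the added ring also counts, with a 2.1-fold lower number from compound 1 to compound 4 (0.33 log units; beyond the scatter), so a single small group on that ring moves the number beyond the scatter. The step of an at least 4.6-fold lower number from compound 2 to compound 4 (0.66 log units; beyond the scatter) is only a floor, as it rests on a limit of the assay: the limit of > 50000 nM in this assay, at which 1 of the 4 values shown sits.

Still open, on these data alone, is whether the lower number depends on methoxy itself. An amine or a carboxylic acid in its place could show whether other groups on that ring act the same way.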